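The source may report more compounds than this note shows. Statements on the series, on what has been measured and on what is new or still open speak of the compounds shown alone.

Measured in a functional assay on HCT-116 cells (Homo sapiens) for inhibition, read by sulforhodamine B assay, with a stated time of 48 h, tested at 50 uM; on this read-out lower numbers stand for less inhibition of growth and higher numbers for more inhibition of growth at the one concentration tested:
- compound 1 `COc1cc(/C=C/C(=O)/C=C/c2cccc3ccccc23)ccc1OCc1cn(CCOc2cc(=O)oc3ccccc23)nn1`: 83%
- compound 2 `COc1cc(/C=C/C(=O)/C=C/c2cccc3ccccc23)ccc1OCc1cn(CCCCCOc2cc(=O)oc3ccccc23)nn1`: 42%
- compound 3 `COc1cc(/C=C/C(=O)/C=C/c2cccs2)ccc1OCc1cn(CCOc2cc(=O)oc3ccccc23)nn1`: 71%

Compound 3 (71%) holds the middle place of the three numbers. Compound 1 lies above it and compound 2 lies below it, both gaps beyond the scatter.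

The next compound is compound 4 `COc1cccc(/C=C/C(=O)/C=C/c2ccc(OCc3cn(CCOc4cc(=O)oc5ccccc45)nn3)c(OC)c2)c1`, still unmeasured. Its change from compound 3 (3-methoxyphenyl in place of thiophen-2-yl on a double-bonded chain carbon bound to a double-bonded chain carbon) sits on a double-bonded chain carbon bound to a double-bonded chain carbon.

One measured step falls at that same place: a number 12 percentage points lower from compound 1 to compound 3 (beyond the scatter). That step is modest and beyond the scatter, and it shows that the group at this place can move the read-out. Among the measured compounds shown here, compound 2 offers no step at this place. For the measured compounds named here, no measured compound carries 3-methoxyphenyl, so the direction rests on thin evidence. A six-membered aromatic ring of carbon only replaces the thiophen-2-yl, so a small move back towards compound 1 is a reasonable expectation, though a smaller one than the measured step.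

The expected step is small and within the scatter (a number 5 percentage points higher from compound 3 to compound 4 (within the scatter)). For compound 4 the estimated value is 76% (expected range 60% to 89%).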

Compound 4, percent growth inhibition at one concentration: 70%
The estimate for compound 4 lay 6 percentage points above the measured number, and the stated range covers the measured number.
By their numbers in this assay, from the lowest: compound 2; then compounds 4 and 3 (each within the scatter of the next); then compound 1.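

In this assay the swap of thiophen-2-yl for 3-methoxyphenyl, on a double-bonded chain carbon bound to a double-bonded chain carbon, reads as a number 1 percentage points lower from compound 3 to compound 4 (within the scatter) and so does not separate the two groups, although a five-membered aromatic ring with 1 hetero atom gives way to a six-membered aromatic ring of carbon only and the heavy atoms go from 5 to 8. Set beside a number 12 percentage points lower from compound 1 to compound 3 (beyond the scatter), the new step of a number 13 percentage points lower from compound 1 to compound 4 (beyond the scatter) shows that naphthalen-1-yl is the one group of the three at this place that stands apart, with both other groups giving lower numbers than it does on the same chain. No measurement shown here accounts for this outcome.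

The compounds shown leave open whether an unsubstituted phenyl, or a phenyl carrying an amine or a carboxylic acid, would stay with compound 3 and compound 4 or move away from them at this place. They also leave open whether the longer chain of compound 2 would go with a similarly low number when paired with thiophen-2-yl or 3-methoxyphenyl.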